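From 4-fluorophenyl to (2-fluorophenyl)carbonyl: notes on compound 3

The compounds below may be only part of what the source reports. "The series", "measured", "known", "first", "only" and "open" are said of these compounds alone.

In a functional assay on A549 cells (Homo sapiens) for antiproliferative activity, read by MTT assay, with a stated time of 24 h (on this read-out lower numbers stand for stronger inhibition and higher numbers for weaker inhibition), compound 1 (`O=C(NNc1ccc(F)cc1)c1cccc(NS(=O)(=O)c2cnc(O)nc2O)c1`) gives > 20000 nM as a limit, not a number. Within the data shown here, compound 2 (`O=C(NNC(=O)c1ccccc1Cl)c1ccc(NS(=O)(=O)c2cnc(O)nc2O)cc1`) gives 1900 nM as the one numeric reading so far. Compound 3 (`O=C(NNC(=O)c1ccccc1F)c1cccc(NS(=O)(=O)c2cnc(O)nc2O)c1`) has no reading yet. It takes (2-fluorophenyl)carbonyl in place of 4-fluorophenyl on an amine nitrogen. Among the measured compounds shown here, no measured step isolates this change, so the expectation stays loose. Compound 2 at 1900 nM shows that numeric readings occur in this series, so a move toward stronger inhibition in this assay is expected for compound 3, of moderate size. For compound 3 a reading at the limit seen for compound 1 also remains possible. The expected change is an at least 2.2-fold lower number from compound 1 to compound 3 (0.34 log units; beyond the scatter) as estimated here. The estimate for compound 3 is 9000 nM with 2500 nM to 30000 nM as its expected range.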

Compound 3, half-maximal inhibitory concentration: 10800 nM
For compound 3 the middle estimate is 1.2-fold (0.08 log units) below the measured one; low and high end bracket the measured number.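

In this assay, (2-fluorophenyl)carbonyl in place of 4-fluorophenyl on an amine nitrogen gives an at least 1.8-fold lower number from compound 1 to compound 3 (0.26 log units; that floor lies within the scatter), the only step shown at this position. The change adds a carbonyl, turning (4-fluorophenyl)amino into ((2-fluorophenyl)carbonyl)amino, and with that group this position yields a numeric reading instead of a limit. The true size of the step stays unknown and only its floor can be stated, because compound 1 stands at a limit of the assay and not at a number: the limit of > 20000 nM in this assay, at which 1 of the 3 values shown sits.

The carbonyl and the fluorine placement change together in this one step, so their shares in it cannot be separated. A (4-fluorophenyl)carbonyl on the same amine nitrogen would separate the two, and an acetyl group would show what the carbonyl does without the aromatic ring.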